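This account rests on a few compounds, and the source may have more. Where it says the series, first, only, none or still open, it means among the compounds named here.

Compound 1, with the structure `CC(C)(C)OC(=O)/C=C1/C(=O)Nc2ccccc21`, was tested in a functional assay on SW480 cells (Homo sapiens) for inhibition, read by CCK-8 assay, with a stated time of 72 h, tested at 20 uM (on this read-out lower numbers stand for less inhibition of growth and higher numbers for more inhibition of growth at the one concentration tested), where compound 1 gives 78.1%. Going by the values given here, its one measured companion is compound 2, with the structure `CN1C(=O)/C(=C/C(=O)OC(C)(C)C)c2ccccc21`, in which a methyl sits on the amide-type nitrogen in the ring instead of a hydrogen; in this assay compound 2 gives 77.8%. The step of a number 0.3 percentage points lower from compound 1 to compound 2 (within the scatter) is within the scatter, so although compound 1 has the higher of the two numbers, the two compounds cannot be told apart on this read-out.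

Compound 3, with the structure `CC(C)c1ccc2c(c1)/C(=C\C(=O)OC(C)(C)C)C(=O)N2`, is not yet measured. It differs from compound 1 in one place: isopropyl in place of hydrogen on an aromatic carbon. Among the compounds with values here, the only measured step, from compound 1 to compound 2, changes the amide-type nitrogen and not the six-membered aromatic ring of carbon only, so no measured step bears directly on this change, and the single step known was within the scatter. Without any further guide, the expectation for the step of a number 0.1 percentage points lower from compound 1 to compound 3 (within the scatter) is therefore one that stays within the usual scatter. On that basis compound 3 is estimated to give about 78% in this assay, with an expected range from 64% to 90%.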

Compound 3, percent growth inhibition at one concentration: 78.5%
The estimate for compound 3 lay 0.5 percentage points below the measured number; the measured number falls inside the stated range.
By their numbers in this assay, from the lowest: compounds 2, 1 and 3 (each within the scatter of the next).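

In this assay, putting isopropyl in place of hydrogen on an aromatic carbon gives a number 0.4 percentage points higher from compound 1 to compound 3 (within the scatter). Going by these compounds alone, this is the first information about the six-membered aromatic ring of carbon only, since the earlier step changed the amide-type nitrogen and left this ring as it was. The result shows that this aromatic carbon can carry isopropyl rather than hydrogen with no difference in growth inhibition that this read-out can separate from the scatter of repeated measurements, although no information is available that could explain this outcome.

As far as these compounds go, a single group at a single place cannot show how far this tolerance extends, so it remains open whether an amine, a carboxylic acid or a longer chain on the same aromatic carbon would give a step beyond the scatter. From the compounds shown here alone, it is also open whether isopropyl would behave the same way on the other aromatic carbons of the ring, and whether compounds that match at the one concentration tested would still match at other concentrations.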